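Working notes: three measured compounds and one to come

The source may hold more compounds than are shown below. What is called first, only, known or untested is meant among the compounds shown, and "the series" means these compounds.

Measured so far:
compound 1 `COc1ccc(/C=C/c2cc(C)no2)cc1OC` — > 100000 nM
compound 2 `COc1cc(/C=C/c2cc(C)[nH]n2)ccc1O` — 32200 nM
compound 3 `CC(=O)/C=C(O)/C=C/c1ccc(O)c(O)c1` — 28600 nM

In a functional assay on DU-145 cells (Homo sapiens) for cytotoxicity, read by MTT assay, with a stated time of 72 h (a higher number here means a weaker inhibitor, a lower number a stronger inhibitor), compound 1 gives > 100000 nM, which is a limit of the assay and not a number. Compound 2 gives 32200 nM in this assay. Compound 3 gives 28600 nM in this assay, and these two values lie within the usual scatter of each other, so no order between compound 2 and compound 3 is claimed. Among the measured compounds shown here, no two measured compounds differ in a single place, so no measured step exists. Compound 1 therefore stands only at the boundary of what this assay reports: the limit of > 100000 nM in this assay, at which 1 of the 3 values shown sits.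

Compound 4 `COc1ccc(/C=C/C(=O)CC(C)=O)cc1OC` is not yet measured. It differs from compound 1 in one place: (2-oxopropyl)carbonyl in place of 3-methyl-1,2-oxazol-5-yl on a double-bonded chain carbon bound to a double-bonded chain carbon.

Because compound 1 sits at the limit of > 100000 nM in this assay, at which 1 of the 3 values shown sits, any reported number for compound 4 would mean a step toward stronger inhibition, while a second limit would mean no change. Compound 3 gives 28600 nM, the closest measured value carrying a chain rather than a ring, and this is taken as the guide. Compound 4 is expected at about 60000 nM, between 20000 nM and 200000 nM. The expected step is an at least 1.6-fold lower number from compound 1 to compound 4 (0.22 log units; that floor lies within the scatter), toward stronger inhibition, with a real chance that only a limit is returned.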

Compound 4, half-maximal inhibitory concentration: 8200 nM
The estimate for compound 4 lay 7.3-fold (0.86 log units) above the measured number, outside the stated range (below it).
By their numbers in this assay, from the lowest: compound 4; then compounds 3 and 2 (each within the scatter of the next). At a limit, above all of these: compound 1.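

In this assay, among the compounds shown here, the exchange of 3-methyl-1,2-oxazol-5-yl for (2-oxopropyl)carbonyl on a double-bonded chain carbon bound to a double-bonded chain carbon gives an at least 12-fold lower number from compound 1 to compound 4 (1.08 log units; beyond the scatter) and is the first single-place step, so the group at this place alone is now seen to move the read-out well beyond the scatter. The two groups match in heavy atoms and in hydrogen-bond donors and acceptors as counted, which leaves the loss of the five-membered aromatic ring and the exchange of its nitrogen for oxygen as the differences in the pair, with neither one singled out by the data. The step gives only a floor and not a size because compound 1 carries a limit of the assay and not a number: the limit of > 100000 nM in this assay, at which 1 of the 4 values shown sits.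

From the compounds shown here alone, the true size of the step stays open, and so does whether it would hold on a core with a different substitution pattern, since this is a single pair. Also open, going by these compounds, is how the read-out at this place would respond to an amine, a carboxylic acid or a longer chain in place of the (2-oxopropyl)carbonyl, which would show whether the open chain as such or its particular atoms carry the step.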